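Swapping the aromatic amide in a glycine transporter series

A few compounds are considered here, and "the series" means these few. Any claim that something is new, unique, unknown or untested is made for them only; others in the source may bear on it.

Compound 1: `CCCS(=O)(=O)N1CC2CCC(NC(=O)c3ccc(Cl)cc3Cl)C2C1`; > 10000 nM
Compound 2: `Cn1cnc(S(=O)(=O)N2CC3CCC(NC(=O)c4ccccc4F)C3C2)c1`; 1820000 nM

In an assay on isolated protein for inhibition of sodium- and chloride-dependent glycine transporter 1 (Homo sapiens) (on this read-out lower numbers stand for stronger inhibition and higher numbers for weaker inhibition), compound 1 reaches only a limit, > 10000 nM (the limit of > 10000 nM in this assay, at which 1 of the 2 values shown sits). In this assay, going by the values given here, compound 2 gives 1820000 nM, the only real number among the two values, so it stands alone as a measured point. Compound 3, `Cn1cnc(S(=O)(=O)N2CC3CCC(NC(=O)c4ccc(Cl)cc4)C3C2)c1`, carries 4-chlorophenyl in place of 2-fluorophenyl on a carbonyl carbon. Among the compounds with values here, no measured step covers this kind of change, so there is no basis for expecting a shift beyond the usual scatter in this assay, and compound 3 is estimated at 1000000 nM, within 200000 nM to 5000000 nM, which means an expected step of a 1.8-fold lower number from compound 2 to compound 3 (0.26 log units; within the scatter).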

Compound 3, half-maximal inhibitory concentration: 1030000 nM
Estimate against measurement, compound 3: 1.0-fold (0.01 log units) below; low and high end bracket the measured number.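

Going by these compounds alone, exchanging the 2-fluorophenyl for 4-chlorophenyl on the carbonyl carbon gives a 1.8-fold lower number from compound 2 to compound 3 (0.25 log units; within the scatter) in this assay, the first step that can be read at this position. A fluorine-bearing and a chlorine-bearing phenyl ring therefore cannot be told apart here, and the numbers for both compounds remain very high. Within the data shown here, nothing measured so far explains this result.

From the compounds shown here alone, whether a pyridine ring, or a phenyl ring carrying an amine or a carboxylic acid, on this carbonyl carbon would give a much lower number remains open.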